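Swapping Fluorine for Iodine on a Well-Tolerated Scaffold

A few compounds are considered here, and "the series" means these few. Any claim that something is new, unique, unknown or untested is made for them only; others in the source may bear on it.

Compound 1, `Fc1cccc(F)c1Cn1ccc2nc(-c3c(F)cccc3F)nc-2c1`: > 100000 nM
Compound 2, `Fc1ccc(Cn2ccc3nc(-c4ccccc4)nc-3c2)cc1`: > 100000 nM

Of the compounds shown here, two of this small set have been tested in an ADME assay on MDBK cells (Bos taurus) for cytotoxicity; a higher number here means that more compound is tolerated, a lower number that less compound is tolerated. Compound 1, `Fc1cccc(F)c1Cn1ccc2nc(-c3c(F)cccc3F)nc-2c1`, reaches > 100000 nM, which is a limit of the assay rather than a measured number. Compound 2, `Fc1ccc(Cn2ccc3nc(-c4ccccc4)nc-3c2)cc1`, likewise gives > 100000 nM, again a limit of the assay and not a number. Both results therefore stand at the same point: the limit of > 100000 nM in this assay, at which 2 of the 2 values shown sit. Within the data shown here, nothing in the numbers so far separates compound 2 from compound 1.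

Compound 3, `Ic1ccc(Cn2ccc3nc(-c4ccccc4)nc-3c2)cc1`, is the next candidate. It differs from compound 2 in a single place: iodo in place of fluoro on an aromatic carbon. Cut one bond further out, the 4-fluorophenyl becomes a 4-iodophenyl, with nothing else altered.

Among the measured compounds shown here, no measured pair in this set shows what such a swap does in this assay, so the expectation rests only on where compound 2 stands. The expected step is an at least 1.2-fold lower number from compound 2 to compound 3 (0.09 log units; that floor lies within the scatter), small and at most slightly downward. Compound 3 is accordingly estimated at 80000 nM, between 20000 nM and 200000 nM, with a fair chance that this assay once more reports only a limit.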

Compound 3, half-maximal cytotoxic concentration: 22000 nM
Compound 3: middle estimate off by 3.6-fold (0.56 log units), on the high side, within the range that was stated.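

In this assay, iodo in place of fluoro on an aromatic carbon gives an at least 4.5-fold lower number from compound 2 to compound 3 (0.65 log units; beyond the scatter), and that step lies beyond the usual scatter of repeated measurements. Among these compounds, compound 3 is thus the first compound in this set to give a measured number rather than a limit, which shows that changing this single atom on the ring, with the rest of the molecule untouched, is enough to make the cells tolerate less compound. The true size of the step remains unknown and only its minimum can be stated, because the starting point for compound 2 is a limit and not a number: the limit of > 100000 nM in this assay, at which 2 of the 3 values shown sit.

The compounds shown leave open whether this drop is particular to iodo or would also appear with chloro, bromo, methyl or an amine at the same place on the ring. They also leave open whether iodo would lower the number to a similar extent on the differently substituted compound 1, so a single step cannot yet be called a general rule for this series.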